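The source may report more compounds than this note shows. Statements on the series, on what has been measured and on what is new or still open speak of the compounds shown alone.

Measured compounds:
Compound 1 `COc1ccc2c(=O)cc(/C=C/[S+](C)[O-])oc2c1O` gives > 10000 nM in a functional assay on DLD-1 cells (Homo sapiens) for inhibition, with a stated time of 48 h (on this read-out lower numbers stand for stronger inhibition and higher numbers for weaker inhibition), which is a limit of the assay and not a number.
Compound 2 `COc1cc2oc(/C=C/[S+](C)[O-])cc(=O)c2cc1O` gives > 10000 nM in this assay, again a limit and not a number.
Compound 3 `C[S+]([O-])/C=C/c1cc(=O)c2ccccc2o1` gives 1000 nM in this assay.

Within the data shown here, compound 3 stands alone as the only numerical value; the other two entries sit at the limit of > 10000 nM in this assay, at which 2 of the 3 values shown sit, and give no number to compare against. Among the measured compounds shown here, no step between measured compounds differing in one place is available, so the series so far gives no measured direction for a single substitution on the fused ring of compound 3.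

Compound 4 `C[S+]([O-])/C=C/c1cc(=O)c2cc(O)ccc2o1` is the next compound to be tested in this assay. It differs from compound 3 by hydroxy in place of hydrogen on an aromatic carbon. For the measured compounds named here, compounds 1 and 2 also carry substitution on the fused ring, but both differ from compound 4 in more than one place, so their values show only that more heavily substituted analogues reached no number here.

For compound 4 a step of a 3.0-fold higher number from compound 3 to compound 4 (0.48 log units; beyond the scatter) towards weaker inhibition is expected, larger than the usual scatter, with a real chance of a limit rather than a number. The estimate for compound 4 is 3000 nM, expected to fall between 800 nM and 10000 nM.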

Compound 4, half-maximal inhibitory concentration: > 10000 nM
Compound 4: only a limit was reported; the forecaster's own chance of this, stated with the estimate: 35%; middle value at least 3.3-fold (0.52 log units) from the limit.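

Hydroxy in place of hydrogen on an aromatic carbon, meta to a fused ring and para to a fused ring, gives an at least 10-fold higher number from compound 3 to compound 4 (1.00 log units; beyond the scatter) in this assay; this is the first readable single-place step in the series, and it runs towards weaker inhibition. Compound 4 gives > 10000 nM, which is a limit of the assay and not a number. The step from compound 2 to compound 4 cannot be read, and compound 3 remains the only compound with a number, so the unsubstituted fused ring is the sole measured reference point: the limit of > 10000 nM in this assay, at which 3 of the 4 values shown sit.

The compounds shown leave open whether the weaker inhibition belongs to hydroxy specifically or would follow any group on this carbon, and a fluorine, an amine or a carboxylic acid here would help separate those two readings. Also open, from the compounds shown here alone, is whether a single hydroxy on another carbon of the same ring gives a similar step, and how far compound 4 truly lies from compound 3 in this assay.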